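Swapping one aryl group near a solubility limit

The compounds below may be only part of what the source reports. "The series", "measured", "known", "first", "only" and "open" are said of these compounds alone.

Compound 1 `CCOC(=O)c1c(-c2ccc(Cl)cc2)[nH]c2cccc(OC)c2c1=O`: > 100000 nM (a limit, not a number)
Compound 2 `CCOC(=O)c1c(-c2ccc(Cl)c(Cl)c2)[nH]c2cc(OC)ccc2c1=O`: 17000 nM

These values come from a physicochemical assay for solubility, in phosphate buffer, at pH 7.4 (on this read-out lower numbers stand for lower solubility and higher numbers for higher solubility), and compound 3 `CCOC(=O)c1c(-c2cccc(OC)c2)[nH]c2cccc(OC)c2c1=O` has not yet been measured there. Compound 1 stands at the limit of > 100000 nM in this assay, at which 1 of the 2 values shown sits, and has no exact number.

Compound 3 keeps the core of compound 1 and carries 3-methoxyphenyl in place of 4-chlorophenyl on an aromatic carbon. Among the measured compounds shown here, no two measured compounds differ in just one place, so no measured step sizes this swap. The expectation is therefore no change beyond the scatter. The expected move is an at least 1.2-fold lower number from compound 1 to compound 3 (0.09 log units; that floor lies within the scatter) in this assay and is only a rough estimate. The range stays wide on the low side because compound 2 gives 17000 nM in this assay and so a number can appear in this small set. For compound 3 the estimated value is 80000 nM (expected range 25000 nM to 150000 nM).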

Compound 3, solubility: > 100000 nM
Compound 3: only a limit was reported (the forecaster's own chance of this, stated with the estimate: 50%); middle value at least 1.2-fold (0.09 log units) from the limit.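

Among the compounds shown here, compound 1 and compound 3 are both reported only as limits in this assay, not as exact numbers, so no step between them can be read: the limit of > 100000 nM in this assay, at which 2 of the 3 values shown sit.

The compounds shown leave open whether 3-methoxyphenyl in place of 4-chlorophenyl shifts this read-out at all, and by how much.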